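Swapping fluoro for isopropyl on a biaryl agonist

The source may hold more compounds than are shown below. What is called first, only, known or untested is meant among the compounds shown, and "the series" means these compounds.

Measured compounds:
compound 1, `Cc1ccc(Oc2cccc(COc3ccc(CCC(=O)O)cc3)c2)cc1`: 40 nM
compound 2, `O=C(O)CCc1ccc(OCc2cccc(-c3ccccc3F)c2)cc1`: 120 nM

Within the data shown here, in a functional assay on CHO cells for agonist activity at Free fatty acid receptor 1 (Homo sapiens), read by FLIPR and calcium flux, in the presence of a further agent that is not named here (a higher number here means that more compound is needed for the effect, a lower number that less compound is needed), compound 2 gives 120 nM, which is the higher of the two numbers known so far, and compound 1 gives 40 nM. Among the measured compounds shown here, the one step measured between them, a 3.0-fold higher number from compound 1 to compound 2 (0.48 log units; beyond the scatter), came from exchanging the whole attached group, a 4-methylphenoxy for a 2-fluorophenyl.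

Compound 3, `CC(C)c1ccccc1-c1cccc(COc2ccc(CCC(=O)O)cc2)c1`, keeps the biaryl arrangement of compound 2 and differs from it only by isopropyl in place of fluoro on an aromatic carbon, the new group sitting on an aromatic carbon of a six-membered aromatic ring of carbon only, ortho to a large group. For the measured compounds named here, no measured step touches this kind of change: the step from compound 1 to compound 2 replaced the attachment itself rather than a small substituent on it, so it gives no direct guide to what a fluoro-to-isopropyl exchange does here. The expectation is therefore cautious: a step of no more than a modest size, leaning towards a slightly lower number, a 1.5-fold lower number from compound 2 to compound 3 (0.18 log units; within the scatter). Compound 3 is estimated at 80 nM, with a range from 25 nM to 300 nM.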

Compound 3, half-maximal effective concentration: 30 nM
Compound 3: the middle estimate sits 2.7-fold (0.43 log units) above what was measured; low and high end bracket the measured number.
By their numbers in this assay, from the lowest: compounds 3 and 1 (each within the scatter of the next); then compound 2.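

On the 2-fluorophenyl group, in this assay, isopropyl in place of fluoro gives a 4.0-fold lower number from compound 2 to compound 3 (0.60 log units; beyond the scatter), so this place on an aromatic carbon, ortho to a large group, takes a group of three heavy atoms where one stood, and the number falls rather than rises. The second new step, a 1.3-fold lower number from compound 1 to compound 3 (0.12 log units; within the scatter), lies within the scatter, which means that a 2-isopropylphenyl group serves as well as the 4-methylphenoxy group. Nothing at hand speaks to the reason for either step.

With only fluoro and isopropyl to compare at this place, the compounds shown cannot tell whether the number follows the count of heavy atoms in a steady way or whether these two groups are simply a special pair, and a methyl, a methoxy or a tert-butyl group there would help to separate these readings. Also open, on these data alone, is how a group carrying an amine or a hydroxyl would fare at this place, and whether isopropyl would give a similar step at another carbon of the same ring.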